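Swapping the Pyrrole of Compound 1 for a Methylfuran

The source may report more compounds than this note shows. Statements on the series, on what has been measured and on what is new or still open speak of the compounds shown alone.

Three measured compounds share one core and differ only in the five-membered ring attached to it. Compound 1 `c1c[nH]c(-c2ccccc2OCC2=NCCN2)c1` gives 99% in a functional assay with Alpha-1A adrenergic receptor (Homo sapiens) as the target, read by calcium flux; on this read-out lower numbers stand for smaller maximal responses and higher numbers for larger maximal responses; compound 2 `c1ccc(-c2ccsc2)c(OCC2=NCCN2)c1` gives 98%, and compound 3 `c1ccc(-c2ncc[nH]2)c(OCC2=NCCN2)c1` gives 122%. On these numbers compound 1 and compound 2 cannot be told apart, and only compound 3 stands above them.

Compound 4 `Cc1ccoc1-c1ccccc1OCC1=NCCN1` is the unmeasured partner of compound 1; the change between them is 3-methylfuran-2-yl in place of 1H-pyrrol-2-yl on an aromatic carbon. Among the measured compounds shown here, two measured steps bear on it. a number 1 percentage points lower from compound 1 to compound 2 (within the scatter) shows that exchanging the pyrrole ring for another five-membered ring with one hetero atom left the maximal response where it was. a number 23 percentage points higher from compound 1 to compound 3 (beyond the scatter) shows a modest rise only when the entering ring carried two hetero atoms. The 3-methylfuran-2-yl ring is again a five-membered ring with one hetero atom, so the step of a number 1 percentage points higher from compound 1 to compound 4 (within the scatter) is expected to stay within the scatter. Compound 4 is therefore estimated at 100%, with a range from 82% to 118%.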

Compound 4, largest response reached (reported as maximum), in percent of the reference or control that the assay uses: 99%
Compound 4: middle estimate off by 1 percentage points, on the high side; the range from low to high includes it.
By their numbers in this assay, from the lowest: compounds 2, 1 and 4 (each within the scatter of the next); then compound 3.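

In this assay, the ring on this aromatic carbon can go from 1 hydrogen-bond donor to 0, gain 1 hydrogen-bond acceptor and carry a methyl group, and the result is still no change at the digits printed from compound 1 to compound 4 (within the scatter), so the maximal response does not depend on the pyrrole's donor hydrogen. The thiophen-3-yl compound gives the same picture, with a number 1 percentage points higher from compound 2 to compound 4 (within the scatter), while the imidazole stands apart, with a number 23 percentage points lower from compound 3 to compound 4 (beyond the scatter), which leaves compound 3 alone beyond the scatter from the three rings with one hetero atom. No evidence at hand explains this grouping.

The 3-methylfuran-2-yl ring brings a new ring and a methyl group together, so their separate contributions would only show against a plain furan-2-yl. Going by these compounds, how a phenyl ring, an amine or a carboxylic acid at this place would behave also remains open.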